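Working notes: from compound 3 to compound 4

A few compounds are considered here, and "the series" means these few. Any claim that something is new, unique, unknown or untested is made for them only; others in the source may bear on it.

Values so far in a functional assay on SMMC-7721 cells (Homo sapiens) for cytotoxicity, read by MTT assay, with a stated time of 24 h (a higher number here means a weaker inhibitor, a lower number a stronger inhibitor), for the measured compounds
- compound 1 `COc1cc(/C=C2\CN(S(=O)(=O)c3ccc(F)cc3)C/C(=C\c3ccccc3F)C2=O)cc(OC)c1` gives 6890 nM as its value
- compound 2 `CC(=O)Nc1ccc(S(=O)(=O)N2C/C(=C\c3cccc([N+](=O)[O-])c3)C(=O)/C(=C/c3ccccc3F)C2)cc1` gives 10200 nM as its value
- compound 3 `CC(=O)Nc1ccc(S(=O)(=O)N2C/C(=C\c3ccc(C#N)cc3)C(=O)/C(=C/c3ccccc3F)C2)cc1` gives 3150 nM as its value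

Compound 3 at 3150 nM holds the lowest of the three numbers, and both other values lie beyond the scatter from it. Compound 1 at 6890 nM is the nearest and compound 2 at 10200 nM is the furthest.

Compound 4 `COc1cc(/C=C2\CN(S(=O)(=O)c3ccc(NC(C)=O)cc3)C/C(=C\c3ccccc3F)C2=O)cc(OC)c1` is still unmeasured. Its change from compound 3 is 3,5-dimethoxyphenyl in place of 4-cyanophenyl on a double-bonded chain carbon bound to a double-bonded ring carbon with the rest of the structure kept.

Going by the values given here, one measured step touches this place, namely a 3.2-fold lower number from compound 2 to compound 3 (0.51 log units; beyond the scatter) and this modest shift comes from a single pair. Among the compounds with values here, no measured pair tests the entering group with all else held. Compound 1 carries 3,5-dimethoxyphenyl at this place but differs from compound 4 elsewhere, so compound 1 at 6890 nM serves only as a loose guide. On that figure, a modest step towards a higher number in this assay is expected, similar in size to the measured step or smaller.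

The expected step is a 2.1-fold higher number from compound 3 to compound 4 (0.31 log units; beyond the scatter) on this thin evidence. The estimate for compound 4 is 6500 nM with an expected range from 2800 nM to 14000 nM in repeat measurements.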

Compound 4, half-maximal inhibitory concentration: 5210 nM
Beside the measured number, compound 4's estimate is 1.2-fold (0.10 log units) above it; measured number inside the range.
By their numbers in this assay, from the lowest: compounds 3, 4, 1 and 2 (each within the scatter of the next, the first and the last beyond it).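

In this assay the entering 3,5-dimethoxyphenyl on a double-bonded chain carbon bound to a double-bonded ring carbon does not separate from either group tested there: the readings are (a 1.7-fold higher number from compound 3 to compound 4 (0.22 log units; within the scatter)) and (a 2.0-fold lower number from compound 2 to compound 4 (0.29 log units; within the scatter)), both within the scatter. Only 4-cyanophenyl and 3-nitrophenyl stand apart at this position (a 3.2-fold lower number from compound 2 to compound 3 (0.51 log units; beyond the scatter)), so among these three groups the single clear difference belongs to that pair, and 3,5-dimethoxyphenyl sits within the scatter of both. Going by these compounds alone, the first pair at the aromatic carbon, acetamido in place of fluoro with 3,5-dimethoxyphenyl held, also stays within the scatter (a 1.3-fold lower number from compound 1 to compound 4 (0.12 log units; within the scatter)), and no supporting data bear on why these readings fall as they do.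

Going by these compounds, whether acetamido and fluoro would also fail to separate with 4-cyanophenyl or 3-nitrophenyl at the chain carbon remains open, since that comparison stands on one pair only. Also open is how a phenyl carrying a carboxylic acid or an amine at this position would read in this assay against the three groups shown.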